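The compounds below may be only part of what the source reports. "The series", "measured", "known", "first", "only" and "open" are said of these compounds alone.

Compound 1 `O=C(CCCCC1CCSS1)Nc1ccc(Br)cn1` and compound 3 `O=C(CCCCC(S)CCS)Nc1ccc(Br)cn1` share a core and differ only in one place: a group of 5 heavy atoms (3 carbon, 2 sulfur; no ring) in place of a group of 5 heavy atoms (3 carbon, 2 sulfur; one five-membered non-aromatic ring with 2 hetero atoms), on a saturated chain carbon, four bonds along the chain from a carbonyl carbon. In a functional assay on Bel-7402 cells (Homo sapiens) for inhibition, read by MTT assay, with a stated time of 24 h, tested at 100 ug/mL (on this read-out lower numbers stand for less inhibition of growth and higher numbers for more inhibition of growth at the one concentration tested), compound 1 gives 45.5%, and compound 3 gives 41.2%, so the change made a number 4.3 percentage points lower from compound 1 to compound 3 (within the scatter). Compound 2 `O=C(CCCCC1CCSS1)Nc1cccc2ccccc12` carries a different core; the difference between the two cores is not broken down here. In this assay compound 2 gives 7.22%, the lowest of the three numbers, and both of the other two compounds stand beyond the scatter above it.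

Compound 4 `O=C(CCCCC(S)CCS)Nc1cccc2ccccc12` has not yet been measured. It differs from compound 2 in exactly the same way that compound 3 differs from compound 1: a group of 5 heavy atoms (3 carbon, 2 sulfur; no ring) in place of a group of 5 heavy atoms (3 carbon, 2 sulfur; one five-membered non-aromatic ring with 2 hetero atoms), on a saturated chain carbon, four bonds along the chain from a carbonyl carbon. Among the measured compounds shown here, that change occurs twice among the four compounds, and the one measured instance of it stayed within the scatter. On that basis the step from compound 2 to compound 4 is expected to be small, estimated at a number 1.2 percentage points lower from compound 2 to compound 4 (within the scatter), resting on the step measured from compound 1 to compound 3, a number 4.3 percentage points lower from compound 1 to compound 3 (within the scatter). Compound 4 is therefore expected to give about 6% in this assay, estimated to fall between 0% and 20%.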

Compound 4, percent growth inhibition at one concentration: "not active" (no number reported)
Compound 4: no number reported; no gap can be computed for the estimate.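

In this assay, among the compounds shown here, compound 4 is reported only as "not active", with no number, so no step from compound 2 to compound 4 can be read. Nothing given here bears on this result. The compounds shown leave open whether replacing the ring with 1,3-disulfanylpropyl changes growth inhibition to the same extent on both cores.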